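The compounds below may be only part of what the source reports. "The series", "measured", "known", "first", "only" and "open" are said of these compounds alone.

Compound 1, with structure `N#Cc1c(F)c(Cl)c(C(C(=O)c2ccc(F)cc2)=C2NCCCN2)c(C#N)c1F`, is a small molecule tested in a functional assay on SK-OV-3 cells (Homo sapiens) for antiproliferative activity, read by MTT assay (a lower number here means a stronger inhibitor, a higher number a weaker inhibitor), where compound 1 gives 8.2 ug/mL. Compound 2, with structure `N#Cc1c(F)c(F)c(C(C(=O)c2ccc(F)cc2)=C2NCCCN2)c(C#N)c1F`, differs from compound 1 by one change, (fluoro in place of chloro on an aromatic carbon), and in this assay compound 2 gives 0.5 ug/mL; that change made a 16-fold lower number from compound 1 to compound 2 (1.21 log units; beyond the scatter). Compound 3, with structure `N#Cc1c(F)c(Cl)c(C(C(=O)c2ccc(F)cc2)=C2NCCCCN2)c(C#N)c1F`, has a different core, and the difference between the two cores is not broken down here. In this assay compound 3 gives 4.6 ug/mL. Compound 4, with structure `N#Cc1c(F)c(F)c(C(C(=O)c2ccc(F)cc2)=C2NCCCCN2)c(C#N)c1F`, is not yet measured; it differs from compound 3 by fluoro in place of chloro on an aromatic carbon, the same change seen from compound 1 to compound 2. Because that earlier change gave a 16-fold lower number from compound 1 to compound 2 (1.21 log units; beyond the scatter), a step of similar size is expected here, a 13-fold lower number from compound 3 to compound 4 (1.12 log units; beyond the scatter). Compound 4 is therefore estimated at 0.35 ug/mL, with a likely range from 0.12 ug/mL to 1.2 ug/mL.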

Compound 4, half-maximal inhibitory concentration: 4.2 ug/mL
Compound 4: middle estimate off by 12-fold (1.08 log units), on the low side; measured number outside the range, above it.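

On the core of compound 3, fluoro in place of chloro on an aromatic carbon gave a 1.1-fold lower number from compound 3 to compound 4 (0.04 log units; within the scatter) and so no readable change, unlike the large step on the core of compound 1. The size of this change therefore did not carry over from one core to the other: the same change on two cores in this assay, a 16-fold lower number (1.21 log units; beyond the scatter) from compound 1 to compound 2 and a 1.1-fold lower number (0.04 log units; within the scatter) from compound 3 to compound 4, 15-fold (1.18 log units) apart, beyond the scatter of two such steps. This shows that a step seen on one core cannot simply be assumed on the other in this series, but two pairs do not show why the cores differ or how the change would behave on a further core.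

The compounds shown leave open how a bromo group, a methoxy group or an amine on the same aromatic carbon would behave on either core.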